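The compounds below may be only part of what the source reports. "The series", "measured", "known", "first", "only" and "open" are said of these compounds alone.

- Compound 1 `O=C(N/N=C/c1ccc2no[n+]([O-])c2c1)c1ccc([N+](=O)[O-])cc1`: 0.9
- Compound 2 `CC(C)(C)c1ccc(C(=O)N/N=C/c2ccc3no[n+]([O-])c3c2)cc1`: 3.8

In a physicochemical assay for lipophilicity, read by HPLC, measured as octanol-water partition (a lower number here means a more polar compound, a higher number a more lipophilic compound), compound 2 stands at 3.8, the higher of the two measured numbers. The next structure is compound 3 `O=C(N/N=C/c1ccc2no[n+]([O-])c2c1)c1ccc(O)cc1`, and the change is hydroxy in place of tert-butyl on an aromatic carbon. For the measured compounds named here, the one measured step bearing on this, a number 2.90 log units higher from compound 1 to compound 2 (beyond the scatter), is large and also concerns tert-butyl on an aromatic carbon. A large fall is therefore expected in this assay, towards the number of compound 1 at 0.9. The expected change is a number 2.90 log units lower from compound 2 to compound 3 (beyond the scatter). The estimated value for compound 3 is 0.9, with an expected range of 0.2 to 1.6.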

Compound 3, partition coefficient: 1.2
The estimate for compound 3 lay 0.30 log units below the measured number; the range from low to high includes it.
By their numbers in this assay, from the lowest: compounds 1 and 3 (each within the scatter of the next); then compound 2.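

In this assay, hydroxy in place of tert-butyl on this aromatic carbon gives a number 2.60 log units lower from compound 2 to compound 3 (beyond the scatter), so a second group now stands far from tert-butyl at this position. Hydroxy in place of nitro gives a number 0.30 log units higher from compound 1 to compound 3 (within the scatter), which means these two quite different groups are not separated here, while tert-butyl stands apart from both. Nothing available explains these steps.

From the compounds shown here alone, it remains open whether an amine, a carboxylic acid or a longer chain on this carbon would read with hydroxy and nitro or with tert-butyl.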